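Removing the Trifluoromethyl Group from Compound 1

The source may hold more compounds than are shown below. What is called first, only, known or untested is meant among the compounds shown, and "the series" means these compounds.

Compound 1 `O=c1oc2ccccc2n1CCN1CCN(c2cccc(C(F)(F)F)c2)CC1` gives 30.2 mg/kg in a functional assay on the whole organism with Mus musculus as the target; on this read-out higher numbers stand for an effect only at larger amounts of compound and lower numbers for an effect already at smaller amounts.
Compound 2 `CN1CCN(CCn2c(=O)oc3cccnc32)CC1` reaches only a limit in this assay.
Compound 3 `O=c1oc2cccnc2n1CN1CCN(c2ccc(F)cc2)CC1` gives 3.5 mg/kg in this assay.

Compound 2 returns > 25 mg/kg in this assay, which is a limit of the assay and not a number, the point described by the limit of > 25 mg/kg in this assay, at which 1 of the 3 values shown sits. Among the two numbers in hand, compound 1 stands at the higher dose. Its nearest neighbour is compound 3, whose dose lies lower by a gap that is beyond the usual scatter of this kind of measurement.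

Compound 4 `O=c1oc2ccccc2n1CCN1CCN(c2ccccc2)CC1` is the unmeasured partner of compound 1. It differs by hydrogen in place of trifluoromethyl on an aromatic carbon, in words: hydrogen in place of trifluoromethyl on an aromatic carbon, meta to a large group. Among the compounds with values here, no pair of measured compounds shows this same change, so no measured step can be borrowed for it. Compound 4 is therefore expected to lie close to compound 1, with the estimated step of a 1.2-fold higher number from compound 1 to compound 4 (0.06 log units; within the scatter) not clearly beyond the scatter, leaning if anything toward a somewhat higher dose. For compound 4 in this assay the estimate is 35 mg/kg, with a likely range from 12 mg/kg to 100 mg/kg.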

Compound 4, dose for half-maximal effect: > 50 mg/kg
Compound 4 gave a limit, no number; the forecaster's own chance of this, stated with the estimate: 30%; middle value at least 1.4-fold (0.15 log units) away from the limit.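

In this assay compound 4 returns > 50 mg/kg, which is a limit of the assay and not a number. This gives the series its first measured step at this place on the aromatic ring: hydrogen in place of trifluoromethyl, meta to a large group, produces an at least 1.6-fold higher number from compound 1 to compound 4 (0.21 log units; that floor lies within the scatter). Only the floor of that step is known, and since it lies within the scatter, the result shows that removing trifluoromethyl brought no effect at smaller amounts of compound but does not establish a real loss, and the upper end of the step stays open: the limit of > 50 mg/kg in this assay, at which 1 of the 4 values shown sits.

The compounds shown leave open whether a chlorine atom, a methoxy group or a nitrile in place of trifluoromethyl on this aromatic carbon would give a number in this assay rather than a limit. Within the data shown here, they also leave open whether hydrogen in place of trifluoromethyl would give a similar step on another core, as no second pair of compounds carries this change.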